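The source may hold more compounds than are shown below. What is called first, only, known or untested is meant among the compounds shown, and "the series" means these compounds.

Three ureas built on the shared core of compound 1 `O=C(Nc1cccc(OCc2cn(-c3ccccc3)nn2)c1)Nc1ccc(Cl)c(C(F)(F)F)c1` have been measured in a functional assay on HepG2 cells (Homo sapiens) for inhibition, read by MTT assay, with a stated time of 72 h; a higher number here means a weaker inhibitor, a lower number a stronger inhibitor; compound 1 gives 1780 nM. Compound 2 `CC(C)c1ccccc1-n1cc(COc2cccc(NC(=O)Nc3ccc(Cl)c(C(F)(F)F)c3)c2)nn1` gives 1900 nM, and compound 3 `O=C(Nc1cccc(OCc2cn(-c3ccccc3F)nn2)c1)Nc1ccc(Cl)c(C(F)(F)F)c1` gives 1520 nM. Compound 3 holds the lowest of the three numbers, but it is separated from compound 1 by a 1.2-fold lower number from compound 1 to compound 3 (0.07 log units; within the scatter) and from compound 2 by a 1.3-fold lower number from compound 2 to compound 3 (0.10 log units; within the scatter), so the three cannot be ordered.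

Compound 4 `O=C(Nc1cccc(OCc2cn(-c3ccccc3Cl)nn2)c1)Nc1ccc(Cl)c(C(F)(F)F)c1` differs from compound 3 in one place: chloro in place of fluoro on an aromatic carbon. Every step measured so far touches the same ring position. From compound 1 to compound 2 the change of hydrogen to isopropyl gave a 1.1-fold higher number from compound 1 to compound 2 (0.03 log units; within the scatter), and the change of hydrogen to fluoro gave a 1.2-fold lower number from compound 1 to compound 3 (0.07 log units; within the scatter). None of these moved the number beyond the scatter, so a third small group at this position is expected to leave it in place, with no step beyond the scatter in either direction: the estimated 1.0-fold lower number from compound 3 to compound 4 (0.01 log units; within the scatter). Compound 4 is therefore expected to give about 1500 nM, within a range of 750 nM to 3000 nM.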

Compound 4, half-maximal inhibitory concentration: 1960 nM
Compound 4: middle estimate off by 1.3-fold (0.12 log units), on the low side; the range from low to high includes it.
By their numbers in this assay, from the lowest: compounds 3, 1, 2 and 4 (each within the scatter of the next).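

In this assay the change from 2-fluorophenyl to 2-chlorophenyl stays within the scatter (a 1.3-fold higher number from compound 3 to compound 4 (0.11 log units; within the scatter)), and so do the two other steps to the new compound (a 1.0-fold higher number from compound 2 to compound 4 (0.01 log units; within the scatter); a 1.1-fold higher number from compound 1 to compound 4 (0.04 log units; within the scatter)). This adds an exchange of one halogen for another to the earlier steps and brings chloro alongside hydrogen, fluoro and isopropyl, so that among these four compounds no group at this position separates from any other beyond the scatter. No measurement is available here that would explain this flat result.

From the compounds shown here alone, whether an amine, a hydroxyl or a carboxylic acid at this position would move the number beyond the scatter remains open. The compounds shown also leave open whether chloro would behave the same way elsewhere on this ring.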